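The source may hold more compounds than are shown below. What is called first, only, known or untested is meant among the compounds shown, and "the series" means these compounds.

In a functional assay on PC-3 cells (Homo sapiens) (a higher number here means a weaker inhibitor of growth, a lower number a stronger inhibitor of growth), compound 1 (`Cc1cc(C)c2c(O)cc(-c3ccc(Cl)cc3)nc2n1`) gives 6310 nM and stands second highest of three numbers. Compound 3 (`COc1ccc(-c2cc(O)c3c(C)cc(C)nc3n2)cc1`) gives 24000 nM and compound 2 (`COc1cccc(-c2cc(=O)c3ccc(C)nc3[nH]2)c1`) gives 33.1 nM as the lowest of the three. Compound 4 (`Cc1ccnc2nc(-c3ccc(Cl)cc3)cc(O)c12`) departs from compound 1 by a single change, hydrogen in place of methyl on an aromatic carbon, next to the ring nitrogen (hydrogen in place of methyl on an aromatic carbon). Among the compounds with values here, only one measured step bears on it, and only indirectly: methoxy in place of chloro on an aromatic carbon (a 3.8-fold higher number from compound 1 to compound 3 (0.58 log units; beyond the scatter)) is modest, lies beyond the scatter and concerns another part of the molecule. Compound 2 differs from compound 1 in more than one place, so its value isolates no single change. Within the data shown here, no measured step removes a methyl, which leaves the direction open. The estimate therefore amounts to a small shift (a 1.3-fold lower number from compound 1 to compound 4 (0.10 log units; within the scatter)), and no step beyond the scatter is expected. For compound 4 the estimated value is 5000 nM with an expected range of 1300 nM to 22000 nM in growth inhibition.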

Compound 4, concentration for 50% growth inhibition: 2880 nM
For compound 4 the middle estimate is 1.7-fold (0.24 log units) above the measured one, and the stated range covers the measured number.
By their numbers in this assay, from the lowest: compound 2; then compound 4; then compound 1; then compound 3.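

The step of a 2.2-fold lower number from compound 1 to compound 4 (0.34 log units; beyond the scatter) in this assay shows that this methyl, on the aromatic carbon next to the ring nitrogen, can be replaced by hydrogen with a modest gain in growth inhibition, so the group is not needed for the activity of this series. It is also the first single change shown that lowers the number, whereas the change at the chloro group, a 3.8-fold higher number from compound 1 to compound 3 (0.58 log units; beyond the scatter), raises it. Nothing available accounts for this shift.

Going by these compounds, whether an ethyl group or an amine on this same carbon would move the number further, and in which direction, remains open. On these data alone, it is also open whether removing this methyl has a similar effect when methoxy replaces the chloro group.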